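The source may hold more compounds than are shown below. What is called first, only, known or untested is meant among the compounds shown, and "the series" means these compounds.

Three compounds have been measured in a functional assay on OVCAR-3 cells (Homo sapiens) for inhibition, read by sulforhodamine B assay, with a stated time of 48 h; a higher number here means a weaker inhibitor of growth, a lower number a stronger inhibitor of growth:

Compound 1, `N#Cc1c(-c2nnc(-c3nn(-c4ccccc4)c(-c4ccccc4)c3C#N)c3nn(-c4ccccc4)cc23)nn(-c2ccccc2)c1-c1ccccc1`, gives 7260 nM.
Compound 2, `N#Cc1c(-c2nnc(-c3nn(-c4ccccc4)c(-c4ccccc4)c3C#N)c3nn(-c4ccc(Cl)cc4)cc23)nn(-c2ccccc2)c1-c1ccccc1`, gives 95800 nM.
Compound 3, `N#Cc1c(-c2nnc(-c3ccccc3)c3nn(-c4ccccc4)cc23)nn(-c2ccccc2)c1-c1ccccc1`, gives 93800 nM.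

Compound 1 and compound 2 differ in one place, (chloro in place of hydrogen on an aromatic carbon), and this change gave a 13-fold higher number from compound 1 to compound 2 (1.12 log units; beyond the scatter). Compound 3 has a different core from compound 1; the difference between the two cores is not broken down here. In this assay compound 3 gives a number close to that of compound 2, within the usual scatter, and a much higher number than compound 1.

Compound 4, `N#Cc1c(-c2nnc(-c3ccccc3)c3nn(-c4ccc(Cl)cc4)cc23)nn(-c2ccccc2)c1-c1ccccc1`, has not been measured. It differs from compound 3 in one place, (chloro in place of hydrogen on an aromatic carbon), the same change, at the same kind of place, as that from compound 1 to compound 2: chloro in place of hydrogen on an aromatic carbon. Within the data shown here, the only measured example of this change is the one from compound 1 to compound 2, which gave a 13-fold higher number from compound 1 to compound 2 (1.12 log units; beyond the scatter); on that single example rests the expectation of a 2.1-fold higher number from compound 3 to compound 4 (0.33 log units; beyond the scatter) for compound 4, although compound 3 already gives a high number and the cores differ, so the step is expected to be smaller and less certain. Compound 4 is therefore estimated at 200000 nM, with a likely range from 60000 nM to 700000 nM.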

Compound 4, concentration for 50% growth inhibition: > 100000 nM
Compound 4: no number, only a limit; the forecaster's own chance of this, stated with the estimate: 35%; the middle value is on the limit's open side.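

In this assay compound 4 gives > 100000 nM, which is a limit of the assay and not a number. Putting 4-chlorophenyl in place of phenyl on this core therefore yields only a floor, an at least 1.0-fold higher number from compound 3 to compound 4 (0.02 log units; that floor lies within the scatter), and the true step could be about as large as the one on the core of compound 1 or far smaller, so the two steps can be compared only this far: the same change on two cores in this assay, a 13-fold higher number (1.12 log units; beyond the scatter) from compound 1 to compound 2 and an at least 1.0-fold higher number (0.02 log units; that floor lies within the scatter) from compound 3 to compound 4; the limit leaves it open whether they differ The result thus fits a change that carries over from one core to the other and equally fits one that does not, so it neither supports nor rules out transfer, and the reading for compound 4 stops where the assay's range ends: the limit of > 100000 nM in this assay, at which 1 of the 4 values shown sits.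

The compounds shown leave open whether a fluoro group, a methoxy group or an amine in place of the chloro, on an aromatic carbon of the same ring, would raise the number as chloro does on the core of compound 1. They also leave open what chloro would do at any other place on that ring, on either core.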